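A few compounds are considered here, and "the series" means these few. Any claim that something is new, unique, unknown or untested is made for them only; others in the source may bear on it.

Compound 1 `CC(=O)O[C@@H]1[C@@H](OC(C)=O)[C@@H](O)[C@@H](CO)O[C@H]1NC(=S)NNC(=O)Cn1cnc2c(N)ncnc21` and compound 2 `CC(=O)O[C@@H]1[C@@H](OC(C)=O)[C@@H](O)CO[C@H]1NC(=S)NNC(=O)Cn1cnc2c(N)ncnc21` share a core that differs from the core of compound 3 `COc1ccc(C(=O)Nc2nc3ccccc3n2CC(=O)NNC(=S)N[C@@H]2O[C@H](CO)[C@H](O)[C@H](OC(C)=O)[C@H]2OC(C)=O)cc1`, and that difference between the two cores is not broken down here. In a functional assay on PG cells (Homo sapiens) for cytotoxicity, read by MTT assay, with a stated time of 48 h (on this read-out lower numbers stand for an effect already at smaller amounts and higher numbers for an effect only at larger amounts of compound), compound 1 gives > 100000 nM, a limit of the assay rather than a number. In this assay compound 2 likewise gives only a limit, > 200000 nM. Going by the values given here, compound 3 is the one compound with a number, giving 82400 nM in this assay. The change from compound 1 to compound 2 is hydrogen in place of hydroxymethyl on a saturated ring carbon, and its step that the two limits leave unreadable from compound 1 to compound 2 cannot be read because the limit of > 100000 nM in this assay, at which 1 of the 3 values shown sits, and the limit of > 200000 nM in this assay, at which 1 of the 3 values shown sits, bound both ends. Compound 4 `COc1ccc(C(=O)Nc2nc3ccccc3n2CC(=O)NNC(=S)N[C@@H]2OC[C@H](O)[C@H](OC(C)=O)[C@H]2OC(C)=O)cc1` is made from compound 3 by the same change, (hydrogen in place of hydroxymethyl on a saturated ring carbon). Since the earlier step left no readable size, the step from compound 3 to compound 4 is expected near zero, a 1.3-fold higher number from compound 3 to compound 4 (0.13 log units; within the scatter), with wide uncertainty. Compound 4 is therefore expected to give about 110000 nM in this assay, estimated to lie between 40000 nM and 300000 nM.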

Compound 4, half-maximal effective concentration: 73700 nM
The estimate for compound 4 lay 1.5-fold (0.17 log units) above the measured number; measured number inside the range.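

In this assay, hydrogen in place of hydroxymethyl on a saturated ring carbon of the core of compound 3 gives a 1.1-fold lower number from compound 3 to compound 4 (0.05 log units; within the scatter), so on this core the change has no effect that can be told from the usual scatter. This does not show that the change behaves alike on both cores, since the same change on the core of compound 1 cannot be read, and compound 1 gives only a limit of the assay: the limit of > 100000 nM in this assay, at which 1 of the 4 values shown sits. Compound 2 likewise gives only a limit of the assay: the limit of > 200000 nM in this assay, at which 1 of the 4 values shown sits.

The compounds shown leave open whether another group on that saturated ring carbon, such as an aminomethyl group, a carboxylic acid or a longer chain like hydroxyethyl, would move the number on the core of compound 3 beyond the scatter. They also leave open how either core would respond if a free hydroxy group stood in place of the acetoxy groups.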